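Swapping the Aryl Group on a Piperazine Amine

The compounds below may be only part of what the source reports. "The series", "measured", "known", "first", "only" and "open" are said of these compounds alone.

Compound 1 `Nc1scc(CN2CCN(c3ccc(OC(F)(F)F)cc3)CC2)c1C(=O)c1ccc(Cl)cc1` and compound 2 `Nc1scc(CN2CCN(c3ccc(C(F)(F)F)cc3)CC2)c1C(=O)c1cccc(C(F)(F)F)c1` share a common core and have both been read in a functional assay on CHO cells with adenosine receptor A1 (Homo sapiens) as the target, read by cAMP accumulation and immunoassay, with a stated time of 6 min, tested at 10 uM; on this read-out higher numbers stand for a weaker effect at the one concentration tested and lower numbers for a stronger effect. In this assay compound 1 gives -74%, the lowest of the two numbers, and compound 2 gives -47%, a value that stands beyond the usual scatter away from compound 1. Compound 3 `Nc1scc(CN2CCN(c3cc(F)ccc3F)CC2)c1C(=O)c1ccc(Cl)cc1` has not yet been measured. It differs from compound 1 in a single place: 2,5-difluorophenyl in place of 4-(trifluoromethoxy)phenyl on an amine nitrogen in a ring. Within the data shown here, no pair of measured compounds differs in only one place, so no measured step guides this change; compound 2 changes in two places at once and shows only that altering the aryl groups can move the number upward. For compound 3 a small step towards a weaker effect in this assay is expected, possibly within the scatter, as a number 16 percentage points higher from compound 1 to compound 3 (beyond the scatter). The estimate for compound 3 in this assay is -58%, within a range from -82% to -28%.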

Compound 3, a percentage reported as activity, at one concentration (the size of the read-out at that concentration, not a potency): -80%
Beside the measured number, compound 3's estimate is 22 percentage points above it; measured number inside the range.
By their numbers in this assay, from the lowest: compounds 3 and 1 (each within the scatter of the next); then compound 2.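

In this assay, among these compounds, the first step that alters only one place gives a number 6 percentage points lower from compound 1 to compound 3 (within the scatter) and so separates the effect of one aryl group from any other alteration. On this amine nitrogen in a ring, 2,5-difluorophenyl, with 8 heavy atoms and 0 hydrogen-bond acceptors, reads alike with 4-(trifluoromethoxy)phenyl, with 11 heavy atoms and 1 hydrogen-bond acceptor, so this read-out does not distinguish the two groups. Nothing shown here offers an explanation for this likeness. Both aryl groups carry fluorine, which leaves open whether an aryl ring bearing an amine or a carboxylic acid, or a longer chain in place of the aryl ring, would read the same. Going by these compounds, with one concentration per compound, how the potencies of compound 1 and compound 3 compare also remains open.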